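Swapping the Ring Tail on a Shared Guanidine Core

The source may report more compounds than this note shows. Statements on the series, on what has been measured and on what is new or still open speak of the compounds shown alone.

Compound 1 `Cc1nc(N)sc1CCCN/C(N)=N/C(=O)NCC(C)CC1CCCCC1` gives 70.8 nM in an assay on membranes from Sf9 cells for displacement of a labelled ligand from histamine H2 receptor (Homo sapiens), read by scintillation counting, with a stated time of 60 min; a higher number here means a weaker inhibitor, a lower number a stronger inhibitor.
Compound 2 `Cc1ccc(CC(C)CNC(=O)/N=C(\N)NCCCc2sc(N)nc2C)cc1` gives 72.4 nM in this assay.

Among these two numbers compound 2 carries the higher one, yet its gap to compound 1, a 1.0-fold higher number from compound 1 to compound 2 (0.01 log units; within the scatter), is too small to count as a real difference. That step replaced a cyclohexyl group with a 4-methylphenyl group on a saturated chain carbon, three bonds along the chain from an amide-type nitrogen, and it left the read-out in this assay essentially unchanged.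

Compound 3 `Cc1nc(N)sc1CCCN/C(N)=N/C(=O)NCC(C)CCCc1ccccc1` is the next variation at the same site: phenethyl in place of 4-methylphenyl on a saturated chain carbon, three bonds along the chain from an amide-type nitrogen. Going by the values given here, the only measured step that bears on this change is the one from compound 1 to compound 2, which shows that exchanging one ring group for another at this position did not move the number beyond the scatter. On that basis the step of a 1.0-fold higher number from compound 2 to compound 3 (0.02 log units; within the scatter) is expected to be small, with no clear direction. The estimate for compound 3 in this assay is 75 nM, with a likely range from 35 nM to 160 nM.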

Compound 3, inhibition constant: 60.3 nM
Compound 3: middle estimate off by 1.2-fold (0.09 log units), on the high side; the range from low to high includes it.
By their numbers in this assay, from the lowest: compounds 3, 1 and 2 (each within the scatter of the next).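

In this assay the phenethyl group gives a 1.2-fold lower number from compound 2 to compound 3 (0.08 log units; within the scatter) and also a 1.2-fold lower number from compound 1 to compound 3 (0.07 log units; within the scatter) when set against the cyclohexyl group. This saturated chain carbon therefore keeps its number within the scatter not only when one ring replaces another, but also when the tail changes from 4-methylbenzyl to 3-phenylpropyl. No measurement is available to explain why these different tails give such similar numbers.

All three tails shown are made of carbon alone, so it remains open whether an amine or a carboxylic acid on the tail would leave the number as undisturbed. From the compounds shown here alone, it is also open whether a longer chain than 3-phenylpropyl would keep the number within the same scatter.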